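Swapping Cyclopentyloxy for Chlorophenyl on a Silent Scaffold

The compounds below may be only part of what the source reports. "The series", "measured", "known", "first", "only" and "open" are said of these compounds alone.

Compound 1 `COc1ccccc1OCCNc1cnn(Cc2ccc(OC)c(OC3CCCC3)c2)c(=O)c1Cl`: > 100000 nM
Compound 2 `COc1ccc(Cn2nc(NCCOc3ccccc3OC)ccc2=O)cc1OC`: > 100000 nM
Compound 3 `COc1ccccc1OCCNc1cnn(Cc2ccc(OC(F)F)c(OC3CCCC3)c2)c(=O)c1Cl`: > 100000 nM

In a functional assay on K562 cells (Homo sapiens) for antiproliferative activity, read by MTT assay, with a stated time of 48 h (on this read-out higher numbers stand for weaker inhibition of growth and lower numbers for stronger inhibition of growth), compound 1 gives > 100000 nM, which is a limit of the assay and not a number. Compound 2 also stands at a limit in this assay. Compound 3 likewise stands at a limit in this assay. All three values therefore sit at the limit of > 100000 nM in this assay, at which 3 of the 3 values shown sit, so compound 1 cannot be placed anywhere except at that limit, and nothing separates it from the other two.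

Going by the values given here, the one pair that differs in a single place is compound 1 and compound 3, where a step that the two limits leave unreadable from compound 1 to compound 3: difluoromethyl in place of methyl on an oxygen on an aromatic ring. Because both ends sit at the limit, the size of that step is not readable.

The change from compound 1 to compound 4 `COc1ccccc1OCCNc1cnn(Cc2ccc(OC)c(-c3cccc(Cl)c3)c2)c(=O)c1Cl` is 3-chlorophenyl in place of cyclopentyloxy on an aromatic carbon. Among the compounds with values here, no measured step touches this position or this kind of exchange, and the only measured step is unreadable, so there is nothing to lean on for direction or size in this assay.

Compound 4 is therefore estimated at 80000 nM, with a range from 15000 nM to 300000 nM. The step of an at least 1.2-fold lower number from compound 1 to compound 4 (0.09 log units; that floor lies within the scatter) that this estimate means is expected to stay within the limit region, with a real number in this assay more likely absent than present.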

Compound 4, concentration for 50% growth inhibition: > 100000 nM
Compound 4 ended at the assay's limit; the forecaster's own chance of this, stated with the estimate: 70%; middle value at least 1.2-fold (0.09 log units) away from the limit.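

The step from compound 1 to compound 4 cannot be read, because both ends sit at a limit and neither is a number: the limit of > 100000 nM in this assay, at which 4 of the 4 values shown sit.

The compounds shown leave open how large the exchange of cyclopentyloxy for 3-chlorophenyl really is, and whether any change to the shared core gives a real number in this assay.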